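This account rests on a few compounds, and the source may have more. Where it says the series, first, only, none or still open, it means among the compounds named here.

Compound 2 `CS/C(=N\C(=O)c1cc2ccccc2s1)NC(=O)c1cc2ccccc2s1` was tested in a functional assay on MCF7 cells (Homo sapiens) for cytotoxicity, read by MTT assay, with a stated time of 72 h (a lower number here means a stronger inhibitor of growth, a higher number a weaker inhibitor of growth), where compound 2 gives 9510 nM. Its two companions sit close by: compound 1 `C[Se]/C(=N\C(=O)c1cc2ccccc2s1)NC(=O)c1cc2ccccc2s1` gives 5070 nM, and compound 3 `O=C(/N=C(/NC(=O)c1ccco1)[Se]Cc1ccccc1)c1ccco1` gives 8800 nM, so none of the three numbers is separated from the others beyond the usual scatter, and no order among them can be read. Compound 4 `O=C(/N=C(/NC(=O)c1cc2ccccc2s1)[Se]Cc1ccccc1)c1cc2ccccc2s1` has not yet been measured. It differs from compound 2 in one place: a group of 8 heavy atoms (7 carbon, 1 selenium; one six-membered aromatic ring of carbon only) in place of a group of 2 heavy atoms (1 carbon, 1 sulfur; no ring), on a carbon with a double bond to nitrogen. Among the compounds with values here, one measured step bears on this change: a 1.9-fold higher number from compound 1 to compound 2 (0.27 log units; within the scatter), which exchanges sulfur for selenium on the same carbon and stays within the scatter. Compound 3 carries the same entering group on a different core and gives a number close to those of compounds 1 and 2, which gives no sign that this group moves the read-out much. A step of no size beyond the scatter is therefore expected for compound 4 in this assay. Compound 4 is expected to give 7000 nM, within a range from 3000 nM to 16000 nM. This estimate means an expected step of a 1.4-fold lower number from compound 2 to compound 4 (0.13 log units; within the scatter).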

Compound 4, concentration for 50% growth inhibition: 37900 nM
Compound 4: middle estimate off by 5.4-fold (0.73 log units), on the low side; the measured number lies above the stated range.
By their numbers in this assay, from the lowest: compounds 1, 3 and 2 (each within the scatter of the next); then compound 4.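

On the shared core, the position on a carbon with a double bond to nitrogen proves sensitive to change: in this assay, phenyl in place of hydrogen on the saturated chain carbon bound to a selenium atom brings a 7.5-fold higher number from compound 1 to compound 4 (0.87 log units; beyond the scatter), and the full exchange of methylsulfanyl for the entering group brings a 4.0-fold higher number from compound 2 to compound 4 (0.60 log units; beyond the scatter). The earlier exchange of sulfur for selenium stayed within the scatter, whereas the added phenyl alone gives a step beyond it. No measurement shown accounts for this loss of growth inhibition.

The compounds shown leave open whether an ethyl or a longer chain on the selenium atom would give a similar step without the ring. As far as these compounds go, it also remains open whether an amine or a carboxylic acid on the phenyl would bring the number back towards that of compound 1.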